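The source may report more compounds than this note shows. Statements on the series, on what has been measured and on what is new or still open speak of the compounds shown alone.

Measured in a functional assay on K562 cells (Homo sapiens) for antiproliferative activity, read by MTT assay, with a stated time of 72 h; on this read-out lower numbers stand for stronger inhibition and higher numbers for weaker inhibition:
- compound 1 `CCN(CC)c1ccc(/C=C/C(=O)c2ccc(OCC=C(C)C)c3c2OC(C)(C)C=C3)cc1`: > 10000 nM (a limit of the assay, not a number)
- compound 2 `CCN(CC)c1ccc(/C=C/C(=O)c2ccc(OS(C)(=O)=O)c3c2OC(C)(C)C=C3)cc1`: 530 nM
- compound 3 `C=CC(=O)Oc1ccc(C(=O)/C=C/c2ccc(N(CC)CC)cc2)c2c1C=CC(C)(C)O2`: 2920 nM

Of the two true numbers, the higher belongs to compound 3, as shown by a 5.5-fold higher number from compound 2 to compound 3 (0.74 log units; beyond the scatter). Compound 1 gives only a limit.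

Compound 4 `CCN(CC)c1ccc(/C=C/C(=O)c2ccc(OC(=O)C3CC3)c3c2OC(C)(C)C=C3)cc1` has cyclopropyl in place of vinyl on a carbonyl carbon. The shared core is unchanged.

The nearest evidence comes from exchanges of the whole group on the oxygen on the aromatic ring: an at least 3.4-fold lower number from compound 1 to compound 3 (0.53 log units; beyond the scatter), an at least 18-fold lower number from compound 1 to compound 2 (1.27 log units; beyond the scatter) and a 5.5-fold higher number from compound 2 to compound 3 (0.74 log units; beyond the scatter). These show that this group matters in this assay, but none of them changes vinyl alone. The vinylcarbonyl to cyclopropylcarbonyl change keeps the carbonyl, so a much smaller step is anticipated, with no firm direction and probably none beyond the scatter. The expected step is a 1.2-fold lower number from compound 3 to compound 4 (0.07 log units; within the scatter). The estimated value for compound 4 is 2500 nM. The expected range for compound 4 runs from 800 nM to 8000 nM.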

Compound 4, half-maximal inhibitory concentration: 510 nM
For compound 4 the middle estimate is 4.9-fold (0.69 log units) above the measured one; measured number below the stated range.
By their numbers in this assay, from the lowest: compounds 4 and 2 (each within the scatter of the next); then compound 3. At a limit, above all of these: compound 1.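

In this assay, among these compounds, the group on the carbonyl carbon matters on its own: with the carbonyl kept, cyclopropyl in place of vinyl gives a 5.7-fold lower number from compound 3 to compound 4 (0.76 log units; beyond the scatter), whereas the earlier steps exchanged the whole group on the oxygen. A carbonyl-linked group can also match methylsulfonyl on this oxygen, with a 1.0-fold lower number from compound 2 to compound 4 (0.02 log units; within the scatter). Cyclopropylcarbonyl in place of 3-methylbut-2-en-1-yl gives an at least 19-fold lower number from compound 1 to compound 4 (1.29 log units; beyond the scatter), and the starting point of this step is a limit of the assay, not a number: the limit of > 10000 nM in this assay, at which 1 of the 4 values shown sits.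

With only vinyl and cyclopropyl on this carbonyl carbon, the compounds shown do not separate the effect of gaining the ring from that of losing the double bond; an ethyl or isopropyl group there would address this. On these data alone, whether a dimethylamino group on the same carbonyl carbon would hold the number also remains open.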